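Halogenated Chalcone Analogues Assessed for Vero Cell Cytotoxicity

The compounds below may be only part of what the source reports. "The series", "measured", "known", "first", "only" and "open" are said of these compounds alone.

Three chalcone-type compounds sharing one core have been tested in an ADME assay on Vero cells (Chlorocebus sabaeus) for cytotoxicity, read by MTT assay; on this read-out lower numbers stand for stronger inhibition and higher numbers for weaker inhibition. Compound 1, `C=CCOc1cc(OC)c(C(=O)/C=C/c2ccccc2Br)c(OCC=C)c1`, gives 13900 nM in this assay, the lowest of the three numbers. Compound 3, `C=CCOc1cc(OC)c(C(=O)/C=C/c2cc(OC)c(OC)c(OC)c2)c(OCC=C)c1`, gives 40900 nM, a value that stands beyond the scatter above that of compound 1. Compound 2, `C=CCOc1cc(OC)c(C(=O)/C=C/c2cc(OCC=C)c(Br)c(OCC=C)c2)c(OCC=C)c1`, gives 96300 nM, the highest of the three and furthest from compound 1. Among the measured compounds shown here, compound 1 therefore stands as the strongest inhibitor of Vero cell viability among the compounds measured so far.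

A fourth compound, compound 4, `C=CCOc1cc(OC)c(C(=O)/C=C/c2ccc(Cl)cc2)c(OCC=C)c1`, has not yet been measured in this assay. It differs from compound 1 in a single place: 4-chlorophenyl in place of 2-bromophenyl on a double-bonded chain carbon bound to a double-bonded chain carbon. The core, the chain and the aryl ring on the far end all stay the same; only the halogen and where it sits on that ring are changed. For the measured compounds named here, no measured pair among compounds 1 to 3 shows this change in isolation, so there is no step to lean on. Judged from the small size of the change, compound 4 is expected to stay close to compound 1, with a step of a 1.1-fold higher number from compound 1 to compound 4 (0.03 log units; within the scatter) that lies within the usual scatter and shows no clear direction. Compound 4 is accordingly estimated at 15000 nM in this assay, within a range from 6000 nM to 40000 nM.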

Compound 4, half-maximal inhibitory concentration: 10400 nM
The estimate for compound 4 lay 1.4-fold (0.16 log units) above the measured number; measured number inside the range.
By their numbers in this assay, from the lowest: compounds 4 and 1 (each within the scatter of the next); then compound 3; then compound 2.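

In this assay, among the compounds shown here, the first step between two compounds that differ in one place is a 1.3-fold lower number from compound 1 to compound 4 (0.13 log units; within the scatter), so the exchange of 2-bromophenyl for 4-chlorophenyl on a double-bonded chain carbon bound to a double-bonded chain carbon leaves the number unchanged within the scatter. This place on the shared core therefore accepts a change of both the halogen and where it sits on the ring without any clear shift in this read-out, something that compounds 1 to 3 could not show, as no two of them formed such a pair. No measurement available here bears on the reason for this result.

Because the halogen and its site change together in this step, the separate contribution of each remains unresolved, and a 4-bromophenyl or a 2-chlorophenyl group at this place would be needed to pull them apart. From the compounds shown here alone, it also remains open whether the number would hold for a phenyl ring carrying an amine or a carboxylic acid in place of the halogen.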